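Chain substituent on the core nitrogen: compound 3 to compound 4

The compounds below may be only part of what the source reports. "The series", "measured", "known", "first", "only" and "open" are said of these compounds alone.

Working notes on the series. Compound 1 `Cn1c(Cc2nn(C)c(=O)c3ccccc23)nnc1SCC(=O)Nc1ccc(Cl)cc1Cl` gives 4500 nM in an assay on NK92 cells for inhibition of interleukin-15 (Homo sapiens), read by AlphaScreen, with stated times of 30 min and 1 h; a higher number here means a weaker inhibitor, a lower number a stronger inhibitor. Compound 2 `Cn1nc(Cc2nnc(SCCCCCCCC(=O)Nc3ccc(Cl)cc3Cl)n2CCC(=O)O)c2ccccc2c1=O` gives 9500 nM in this assay. Compound 3 `Cn1c(Cc2nn(CCC=O)c(=O)c3ccccc23)nnc1SCC(=O)Nc1ccc(Cl)cc1Cl` gives 20000 nM in this assay and stands highest of the three numbers, with compound 2 nearest and compound 1 furthest. For the measured compounds named here, the one single-point step on record, a 4.4-fold higher number from compound 1 to compound 3 (0.65 log units; beyond the scatter), shows that a group placed on the chain bound to the aromatic nitrogen moves the number by a modest amount. Compound 4 `CN(C)CCCn1nc(Cc2nnc(SCC(=O)Nc3ccc(Cl)cc3Cl)n2C)c2ccccc2c1=O` differs from compound 3 by (dimethylamino)methyl in place of formyl on a saturated chain carbon, two bonds along the chain from an aromatic nitrogen. Going by the values given here, no measured step exchanges one chain terminus for another, so the direction is open; the step from compound 1 to compound 3 only sets the scale of what a chain change has done here. Compound 4 is therefore expected to sit near compound 3, with an estimated step of a 1.7-fold lower number from compound 3 to compound 4 (0.22 log units; within the scatter) that may fall within the scatter. The estimate for compound 4 in this assay is 12000 nM, with a range from 3500 nM to 40000 nM.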

Compound 4, half-maximal inhibitory concentration: > 30000 nM
Compound 4 ended at the assay's limit (the forecaster's own chance of this, stated with the estimate: 15%); middle value at least 2.5-fold (0.39 log units) away from the limit.
By their numbers in this assay, from the lowest: compound 1; then compound 2; then compound 3. At a limit, above all of these: compound 4.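

Compound 4 gives a limit of the assay rather than a number in this assay, so its true value stays unresolved: the limit of > 30000 nM in this assay, at which 1 of the 4 values shown sits.
With 2-(dimethylamino)ethyl in place of hydrogen on the saturated chain carbon bound to the aromatic nitrogen, the result is an at least 6.6-fold higher number from compound 1 to compound 4 (0.82 log units; beyond the scatter), so a second chain, like formylmethyl in a 4.4-fold higher number from compound 1 to compound 3 (0.65 log units; beyond the scatter), gives a higher number than the hydrogen of compound 1. The exchange of chain termini gives an at least 1.5-fold higher number from compound 3 to compound 4 (0.17 log units; that floor lies within the scatter), a floor that does not by itself separate the dimethylamino end from the formyl end.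

From the compounds shown here alone, how far compound 4 lies past the limit remains open. Also open, going by these compounds, is whether a carboxylic acid or a primary amine at the end of this chain, or a shorter chain carrying either group, would return the number to that of compound 1.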